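The source may report more compounds than this note shows. Statements on the series, on what has been measured and on what is new or still open speak of the compounds shown alone.

Three analogues built on one shared core have been measured in a functional assay on SW480 cells (Homo sapiens) for cytotoxicity, read by MTT assay, with a stated time of 48 h; on this read-out higher numbers stand for weaker inhibition and lower numbers for stronger inhibition. Compound 1 `O=c1ccoc2cc(OCc3cn(Cc4cccc(Cl)c4)nn3)ccc12` gives 12900 nM, and compound 2 `O=c1ccoc2cc(OCc3cn(Cc4ccc([N+](=O)[O-])cc4)nn3)ccc12` gives 19300 nM. For compound 3 `N#Cc1ccc(Cn2cc(COc3ccc4c(=O)ccoc4c3)nn2)cc1` the assay reports only a limit, > 100000 nM. Compound 4 `COc1ccc(Cn2cc(COc3ccc4c(=O)ccoc4c3)nn2)cc1` is not yet measured; it differs from compound 3 by methoxy in place of cyano on an aromatic carbon. The nearest measured step, an at least 5.1-fold higher number from compound 2 to compound 3 (0.71 log units; beyond the scatter), likewise exchanges one group para to a large group on the same ring, and an at least 7.7-fold higher number from compound 1 to compound 3 (0.88 log units; beyond the scatter) points the same way, leaving compound 3 the weaker member in each. Because compound 3 sits at the limit of > 100000 nM in this assay, at which 1 of the 3 values shown sits, any change for compound 4 can only be downward or flat. A step of an at least 2.5-fold lower number from compound 3 to compound 4 (0.39 log units; beyond the scatter) is expected. Compound 4 is estimated at 40000 nM, within 10000 nM to 150000 nM.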

Compound 4, half-maximal inhibitory concentration: 20400 nM
The estimate for compound 4 lay 2.0-fold (0.29 log units) above the measured number; measured number inside the range.
By their numbers in this assay, from the lowest: compounds 1, 2 and 4 (each within the scatter of the next). At a limit, above all of these: compound 3.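

In this assay compound 3 remains only a limit, > 100000 nM. Methoxy in place of cyano on the same aromatic carbon gives an at least 4.9-fold lower number from compound 3 to compound 4 (0.69 log units; beyond the scatter), so among these para groups only cyano stands apart. Methoxy in place of nitro gives a 1.1-fold higher number from compound 2 to compound 4 (0.02 log units; within the scatter), and 4-methoxyphenyl in place of 3-chlorophenyl gives a 1.6-fold higher number from compound 1 to compound 4 (0.20 log units; within the scatter), which places compound 4 with compound 1 and compound 2, with no order among them.

The compounds shown leave open whether an amine or a carboxylic acid at this position would fall with compound 3 or with the other three. They also leave open whether a longer chain in place of methoxy would keep the number of compound 4.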